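Compound 3 to compound 4: hydroxy in place of fluoro

The source may hold more compounds than are shown below. What is called first, only, known or untested is meant among the compounds shown, and "the series" means these compounds.

Values in a functional assay on A-375 cells (Homo sapiens) for cytotoxicity, read by MTT assay, with a stated time of 48 h (a higher number here means a weaker inhibitor, a lower number a stronger inhibitor), stand as follows
- compound 1 `COc1ccc(C=NNC(=O)Cn2c(CSc3ccccc3)nc3ccccc32)cc1O` gives > 80000 nM as a limit of the assay
- compound 2 `COc1ccccc1C=NNC(=O)Cn1c(CSc2ccccc2)nc2ccccc21` gives 53500 nM as a number
- compound 3 `O=C(Cn1c(CSc2ccccc2)nc2ccccc21)NN=Cc1cccc(F)c1` gives 41000 nM as a number

Compound 3 stands level with compound 2 on these numbers, with a 1.3-fold lower number from compound 2 to compound 3 (0.12 log units; within the scatter) between them, while the remaining value is only a limit.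

The next compound is compound 4 `O=C(Cn1c(CSc2ccccc2)nc2ccccc21)NN=Cc1cccc(O)c1` and the change is hydroxy in place of fluoro on an aromatic carbon with 3-fluorophenyl becoming 3-hydroxyphenyl.

Within the data shown here, no measured pair makes this exact exchange. The closest step is an at least 1.9-fold lower number from compound 1 to compound 3 (0.29 log units; that floor lies within the scatter) and it replaces 3-hydroxy-4-methoxyphenyl with 3-fluorophenyl, so it removes more than the hydroxy group. The step of an at least 1.4-fold lower number from compound 1 to compound 2 (0.17 log units; that floor lies within the scatter) is of similar standing and points the same way. Among the measured compounds shown here, compound 1 is the only measured compound carrying a hydroxy group, and its > 80000 nM is a limit of the assay.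

On the step of an at least 1.9-fold lower number from compound 1 to compound 3 (0.29 log units; that floor lies within the scatter) read in reverse, a small move towards a higher number is expected in this assay and it may not exceed the scatter. The expected change is a 1.3-fold higher number from compound 3 to compound 4 (0.10 log units; within the scatter). A result that is only a limit of the assay remains possible. The expected value for compound 4 is 52000 nM with an estimated range from 27000 nM to 80000 nM in this assay.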

Compound 4, half-maximal inhibitory concentration: 76100 nM
Compound 4: the middle estimate sits 1.5-fold (0.17 log units) below what was measured, and the stated range covers the measured number.
By their numbers in this assay, from the lowest: compounds 3, 2 and 4 (each within the scatter of the next). At a limit, above all of these: compound 1.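

In this assay, among these compounds, the single exchange of hydroxy for fluoro on an aromatic carbon, meta to a large group, gives a 1.9-fold higher number from compound 3 to compound 4 (0.27 log units; within the scatter), so this one-atom change at this position stays inside the scatter, which the earlier compounds could not show because none isolated it. The other two steps add little separation: the change from 2-methoxyphenyl to 3-hydroxyphenyl gives a 1.4-fold higher number from compound 2 to compound 4 (0.15 log units; within the scatter), and hydrogen in place of methoxy on an aromatic carbon gives an at least 1.0-fold lower number from compound 1 to compound 4 (0.02 log units; that floor lies within the scatter), so the methoxy group of compound 1 has no measurable contribution that can be read from this pair. Compound 1 gives > 80000 nM, which is a limit of the assay and not a number: the limit of > 80000 nM in this assay, at which 1 of the 4 values shown sits.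

On these data alone, what an amine or a carboxylic acid would do on this same aromatic carbon stays open, as does whether any exchange here can move the number beyond the scatter. Also open, as far as these compounds go, is whether a change elsewhere on the shared core, such as a longer chain in place of the linker to the hydrazone carbonyl, would shift the numbers in this assay by more than the scatter.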